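A few compounds are considered here, and "the series" means these few. Any claim that something is new, unique, unknown or untested is made for them only; others in the source may bear on it.

Measured so far:
- compound 1 `CCC(C)(C)Cc1c[nH]c(CCc2ccc(-c3cccc(C)n3)cc2)n1`, in a functional assay on HEK293 cells for agonist activity at Bombesin receptor subtype-3 (Mus musculus), read by luminescence and calcium flux, with a stated time of 10 min (a lower number here means that less compound is needed, a higher number that more compound is needed for the effect), compound 1 gives 19 nM
- compound 2 `CCC(C)(C)Cc1c[nH]c(CCc2ccc(-c3ccncc3)cc2)n1`, compound 2 gives 15 nM
- compound 3 `CCC(C)(C)Cc1c[nH]c(CCc2ccc(-n3cccn3)cc2)n1`, compound 3 gives 9 nM

Compound 3 has the lowest number of the three: there is a 1.7-fold lower number from compound 2 to compound 3 (0.22 log units; within the scatter), and there is a 2.1-fold lower number from compound 1 to compound 3 (0.32 log units; beyond the scatter), while a 1.3-fold lower number from compound 1 to compound 2 (0.10 log units; within the scatter). Compound 4 `CCC(C)(C)Cc1c[nH]c(CCc2ccc(-c3cccc(C#N)n3)cc2)n1` differs from compound 3 by 6-cyanopyridin-2-yl in place of 1H-pyrazol-1-yl on an aromatic carbon. Within the data shown here, the step that bears on it most is the one between compound 1 and compound 3, which carries a related six-membered ring bearing a methyl in place of the nitrile: a 2.1-fold lower number from compound 1 to compound 3 (0.32 log units; beyond the scatter). Reversing that pattern, a modest rise is expected in this assay for compound 4, roughly a 1.9-fold higher number from compound 3 to compound 4 (0.28 log units; within the scatter). Compound 4 is therefore estimated at 17 nM, with a range from 7 nM to 40 nM.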

Compound 4, half-maximal effective concentration: 26 nM
Compound 4: middle estimate off by 1.5-fold (0.18 log units), on the low side; measured number inside the range.
By their numbers in this assay, from the lowest: compounds 3, 2, 1 and 4 (each within the scatter of the next, the first and the last beyond it).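

Against 1H-pyrazol-1-yl, a second substituted pyridin-2-yl group now gives a step beyond the scatter in this assay (a 2.9-fold higher number from compound 3 to compound 4 (0.46 log units; beyond the scatter)), so compound 1 and compound 4 go the same way. Within the six-membered rings the picture stays flat, with nitrile for methyl (a 1.4-fold higher number from compound 1 to compound 4 (0.14 log units; within the scatter)) and with 6-cyanopyridin-2-yl for pyridin-4-yl (a 1.7-fold higher number from compound 2 to compound 4 (0.24 log units; within the scatter)) both inside the scatter. No measurement at hand explains these steps.

Open, going by these compounds, is whether the five-membered ring itself matters, which a 1H-imidazol-1-yl or a methyl-bearing pyrazole at this place could test. Also open, on these data alone, is how an amine or a carboxylic acid on the pyridine ring would compare with the nitrile.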